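Swapping a Pyridine Arm for a Nitrophenyl Arm

A few compounds are considered here, and "the series" means these few. Any claim that something is new, unique, unknown or untested is made for them only; others in the source may bear on it.

Compound 3 `Cc1cc(Nc2nn(Cc3ccncc3)c(=O)c3ccccc23)n[nH]1` gives 20200 nM in a functional assay on HCT-116 cells (Homo sapiens) for cytotoxicity, read by CellTiter-Glo, with a stated time of 5 days (on this read-out higher numbers stand for weaker inhibition and lower numbers for stronger inhibition), the highest number among the three measured compounds. Compound 2 `Cc1cc(Nc2nn(CC(C)C)c(=O)c3ccccc23)n[nH]1` gives 1100 nM in this assay, and compound 1 `Cc1cc(Nc2nn(Cc3ccc(S(C)(=O)=O)cc3)c(=O)c3ccccc23)n[nH]1` gives 1700 nM. The step of an 18-fold higher number from compound 2 to compound 3 (1.26 log units; beyond the scatter) shows how sharply the number rose when the pyridin-4-yl group entered. Compound 4 `Cc1cc(Nc2nn(Cc3ccc([N+](=O)[O-])cc3)c(=O)c3ccccc23)n[nH]1` differs from compound 3 in one place: 4-nitrophenyl in place of pyridin-4-yl on a saturated chain carbon bound to an aromatic nitrogen. Among the measured compounds shown here, no measured step covers this exact change, but compound 1, which also carries a substituted phenyl on a saturated chain carbon bound to an aromatic nitrogen, sits well below compound 3 in this assay. A drop is therefore expected, namely an 8.1-fold lower number from compound 3 to compound 4 (0.91 log units; beyond the scatter). Compound 4 is estimated at 2500 nM, with a range from 800 nM to 8000 nM.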

Compound 4, half-maximal inhibitory concentration: 1400 nM
Compound 4: middle estimate off by 1.8-fold (0.25 log units), on the high side; measured number inside the range.
By their numbers in this assay, from the lowest: compounds 2, 4 and 1 (each within the scatter of the next); then compound 3.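

Putting 4-nitrophenyl in place of pyridin-4-yl gives a 14-fold lower number from compound 3 to compound 4 (1.16 log units; beyond the scatter), so the weak number of compound 3 does not hold for every six-membered aromatic ring at this place. Other changes at the same arm leave no clear difference: there is a 1.2-fold lower number from compound 1 to compound 4 (0.08 log units; within the scatter) with nitro in place of methylsulfonyl on an aromatic carbon, and a 1.3-fold higher number from compound 2 to compound 4 (0.10 log units; within the scatter) with 4-nitrophenyl in place of isopropyl. Nothing available explains why the pyridin-4-yl arm stands apart.

On these data alone, it remains open whether an unsubstituted phenyl would sit with compound 4 or with compound 3, and whether an amine in place of nitro would keep the number of compound 4.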